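The compounds below may be only part of what the source reports. "The series", "measured", "known", "first", "only" and "open" are said of these compounds alone.

The measured compounds in an assay for inhibition of Indoleamine 2,3-dioxygenase 1 (Homo sapiens), read by spectrophotometry, with a stated time of 180 min, tested at 10 uM; a lower number here means a weaker effect, a higher number a stronger effect of the compound at the concentration tested:

Compound 1 `O=C(O)c1ccc(CNc2cc(Br)cc3[nH]ncc23)cc1` gives 49%
Compound 2 `O=C(CNc1cc(Br)cc2[nH]ncc12)NC1CCOCC1` gives 8%
Compound 3 `O=C(O)c1ccc(C(CO)Nc2cc(Br)cc3[nH]ncc23)cc1` gives 19%

Compound 1 stands highest of the three numbers. Compound 3 is nearest to it and compound 2 furthest, and both gaps lie beyond the usual scatter. Going by the values given here, the only step between compounds that differ in one place runs a number 30 percentage points lower from compound 1 to compound 3 (beyond the scatter), where a hydroxymethyl enters in place of hydrogen on a saturated chain carbon bound to an aromatic carbon and a nitrogen on an aromatic ring.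

Compound 4 `Oc1ccc(CNc2cc(Br)cc3[nH]ncc23)cc1` differs from compound 1 in another way: hydroxy in place of carboxy on an aromatic carbon. Among the compounds with values here, no measured step touches the carboxy of compound 1, so the step to compound 3 cannot be read across; it concerns a different place in the molecule. With nothing to point in either direction, the author expects a step of modest size, if any, a number 11 percentage points lower from compound 1 to compound 4 (beyond the scatter), with the number for compound 4 more likely to fall below that of compound 1 than above it. Compound 4 is therefore estimated at 38%, within a range from 15% to 62%.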

Compound 4, a percentage reported as inhibition, at one concentration (the size of the read-out at that concentration, not a potency): 70%
Estimate against measurement, compound 4: 32 percentage points below, and the stated range ends below it.
By their numbers in this assay, from the lowest: compound 2; then compound 3; then compound 1; then compound 4.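

In this assay hydroxy in place of carboxy on this aromatic carbon gives a number 21 percentage points higher from compound 1 to compound 4 (beyond the scatter), so within these compounds the carboxy is not required for the inhibition seen at the concentration tested. The earlier step concerned only the saturated chain carbon and lowered the number, whereas this change at a different place raises it, even though the entering group has fewer heavy atoms and the counts of hydrogen-bond donors and acceptors stay the same. Nothing at hand explains the rise.

Going by these compounds, it remains open how an amine, a methoxy or plain hydrogen on the same aromatic carbon would compare with the hydroxy of compound 4. On these data alone, it is also open whether a hydroxymethyl on the chain carbon would lower the number with hydroxy present, as it does with carboxy present.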